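The source may hold more compounds than are shown below. What is called first, only, known or untested is meant among the compounds shown, and "the series" means these compounds.

All compounds here share one core and were tested in a functional assay on OVCAR-3 cells (Homo sapiens) for antiproliferative activity, read by MTT assay, with a stated time of 24 h; a lower number here means a stronger inhibitor, a higher number a weaker inhibitor. Compound 1 `O=c1[nH]cc(S(=O)(=O)Nc2ccccc2-c2cn(-c3ccccc3)nn2)c(=O)[nH]1` gives 6650 nM in this assay. Compound 2 `O=c1[nH]cc(S(=O)(=O)Nc2cccc(-c3cn(-c4ccc(F)cc4)nn3)c2)c(=O)[nH]1` reaches only a limit, > 20000 nM, so for it no number is known. Among the compounds with values here, compound 3 `O=c1[nH]cc(S(=O)(=O)Nc2ccc(-c3cn(-c4ccccc4F)nn3)cc2)c(=O)[nH]1` gives 8030 nM in this assay; this value and that of compound 1 lie within the usual scatter of each other, so the two cannot be told apart, and compound 3 is one of only two compounds for which a number rather than a limit exists. Compound 4 `O=c1[nH]cc(S(=O)(=O)Nc2ccc(-c3cn(-c4cccc(Cl)c4)nn3)cc2)c(=O)[nH]1` has not yet been measured. It differs from compound 3 in one place: 3-chlorophenyl in place of 2-fluorophenyl on an aromatic nitrogen. Within the data shown here, no step between two measured compounds that differ in a single place is available, so there is no measured guide to what such a change does. The numbers of compound 1 and compound 3 show that two compounds with different groups on that ring nitrogen land close together, which suggests a change there need not move the value far. The expected step is therefore small, a 1.0-fold lower number from compound 3 to compound 4 (0.00 log units; within the scatter), in no clear direction beyond the scatter. Compound 4 is estimated at 8000 nM, within a range of 3000 nM to 20000 nM.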

Compound 4, half-maximal inhibitory concentration: 2750 nM
For compound 4 the middle estimate is 2.9-fold (0.46 log units) above the measured one, outside the stated range (below it).
By their numbers in this assay, from the lowest: compound 4; then compounds 1 and 3 (each within the scatter of the next). At a limit, above all of these: compound 2.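

Within the data shown here, until now no two measured compounds differed in a single place, and what a change on this ring nitrogen does could only be guessed. In this assay there is now a first direct reading: a 2.9-fold lower number from compound 3 to compound 4 (0.47 log units; beyond the scatter), a modest step but a real one. The group on the aromatic nitrogen can therefore move the value, even though 2-fluorophenyl and 3-chlorophenyl have the same count of heavy atoms and neither carries hydrogen-bond donors or acceptors. The step changes the halogen and its ring position together, the data cannot separate the two, and no measurement shown explains the change.

Still open, as far as these compounds go, is what 3-fluorophenyl or 2-chlorophenyl would give on the same nitrogen, since that pair would tell the halogen apart from its ring position, and whether a carboxylic acid or an amine on that phenyl ring would shift the number further. Compound 1 and compound 2 differ from compound 4 in more than one place, and they cannot settle either question.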